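The source may report more compounds than this note shows. Statements on the series, on what has been measured and on what is new or still open speak of the compounds shown alone.

Within the data shown here, compound 3 `O=C1NCCN1c1ccc(S(=O)(=O)Nc2ccc(Br)cc2)cc1` is the one member of this small set to give an actual number in a functional assay on MCF7 cells (Homo sapiens) for antiproliferative activity, read by sulforhodamine B assay, with a stated time of 48 h (a lower number here means a stronger inhibitor, a higher number a weaker inhibitor), where compound 3 gives 240 nM. Its two companions carry an alkyl group where compound 3 carries bromine. Compound 1 `CC(C)Cc1ccc(NS(=O)(=O)c2ccc(N3CCNC3=O)cc2)cc1` reaches only the limit of the measurement, giving > 1000 nM in this assay. Compound 2 `O=C1NCCN1c1ccc(S(=O)(=O)Nc2ccc(C3CCCCC3)cc2)cc1` likewise sits at the limit, giving > 1000 nM in this assay. These two limits, (the limit of > 1000 nM in this assay, at which 2 of the 3 values shown sit), leave a step that the two limits leave unreadable from compound 1 to compound 2. Against compound 3 the steps do read: an at least 4.1-fold lower number from compound 1 to compound 3 (0.61 log units; beyond the scatter), and an at least 4.1-fold lower number from compound 2 to compound 3 (0.61 log units; beyond the scatter). Compound 4 `CCc1cccc(NS(=O)(=O)c2ccc(N3CCNC3=O)cc2)c1` makes a related move: 3-ethylphenyl in place of 4-bromophenyl on a sulfonamide nitrogen. Both measured steps in which bromine replaced an alkyl group lowered the number well beyond the scatter, so putting an alkyl group back in is expected to raise it again, though ethyl is a shorter chain than isobutyl or cyclohexyl, which leaves the size of the rise uncertain. The step expected is a 6.3-fold higher number from compound 3 to compound 4 (0.80 log units; beyond the scatter). Compound 4 is therefore estimated at 1500 nM, in a range from 400 nM to 6000 nM.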

Compound 4, half-maximal inhibitory concentration: 130 nM
The estimate for compound 4 lay 12-fold (1.06 log units) above the measured number; measured number outside the range, below it.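

With a 1.8-fold lower number from compound 3 to compound 4 (0.27 log units; within the scatter), the 3-ethylphenyl and 4-bromophenyl groups on the sulfonamide nitrogen cannot be told apart in this assay. The earlier steps shown here favoured bromine over isobutyl and cyclohexyl, but compound 4 goes against any general rule that an alkyl group on this ring costs activity. Bromine is therefore not required on this ring for a measurable number in this assay.

The change swaps the group and also moves it on the ring, so the compounds shown do not separate the effect of ethyl from the effect of its place; a 4-ethylphenyl or 3-bromophenyl group on the same nitrogen would do so. How a 3-butylphenyl or 3-aminophenyl group would behave also stays open, and compound 1 and compound 2 remain limits rather than numbers: the limit of > 1000 nM in this assay, at which 2 of the 4 values shown sit.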